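From Carboxy to (2-Chlorophenyl)carbamoyl on Compound 1

The compounds below may be only part of what the source reports. "The series", "measured", "known", "first", "only" and "open" are said of these compounds alone.

Three related compounds have been tested for their effect on the growth of cultured cells. In a functional assay on Bel-7402 cells (Homo sapiens) for inhibition, read by MTT assay, with a stated time of 24 h, tested at 100 ug/mL (a higher number here means more inhibition of growth at the concentration tested, a lower number less inhibition of growth), compound 1 (`O=C(O)CCCCC(CCSC(=O)c1ccccc1)SC(=O)c1ccccc1`) gives 81%. Under the same conditions, compound 2 (`O=C(CCCCC1CCSS1)Nc1ccc(OC(F)(F)F)cc1`) gives 78.4%, and these two results lie within the usual scatter of each other. Compound 1 therefore sits at the top of the numbers available, but it shares that place with compound 2. The third compound, compound 3 (`O=C(CCCCC(S)CCS)Nc1ccccc1Cl`), is reported in this assay as "not active" (no number reported), with no number attached.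

The next compound is compound 4 (`O=C(CCCCC(CCSC(=O)c1ccccc1)SC(=O)c1ccccc1)Nc1ccccc1Cl`). It keeps the core of compound 1 and places (2-chlorophenyl)amino in place of hydroxy on a carbonyl carbon. Going by the values given here, no measured pair here differs by a single change, so the data offer no direct guide to the size of this step. The evidence points in two directions. Compound 3 carries the same (2-chlorophenyl)amino group and is reported as "not active" (no number reported), yet its core differs from that of compound 4. Compound 2 has no carboxy group and still gives 78.4%. A moderate fall with wide uncertainty is therefore expected, estimated as a number 26 percentage points lower from compound 1 to compound 4 (beyond the scatter). For compound 4, the expected value in this assay is 55%, with an estimated range from 20% to 85%.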

Compound 4, percent growth inhibition at one concentration: "not active" (no number reported)
No number was reported for compound 4, so the estimate cannot be set against anything.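

Going by these compounds alone, compound 4 is reported as "not active" in this assay, with no number attached, so no step from compound 1 to compound 4 can be read. Nothing measured here explains this result. As far as these compounds go, what stays open is how large the effect on growth inhibition is when (2-chlorophenyl)carbamoyl replaces carboxy on the core of compound 1.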